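Replacing 4-chlorophenyl with 2-aminophenyl: lipophilicity notes

The compounds below may be only part of what the source reports. "The series", "measured", "known", "first", "only" and "open" are said of these compounds alone.

Measured so far in a physicochemical assay for lipophilicity; on this read-out higher numbers stand for higher lipophilicity and lower numbers for lower lipophilicity:
compound 1, `CCOC(=O)C1=C(C)NC(=S)NC1c1cn(C(=O)CNc2ccccc2Cl)c2ccccc12`: 3.44
compound 2, `CCOC(=O)C1=C(C)NC(=S)NC1c1cn(C(=O)CNc2ccc([N+](=O)[O-])cc2C)c2ccccc12`: 3.34
compound 3, `CCOC(=O)C1=C(C)NC(=S)NC1c1cn(C(=O)CNc2ccc(Cl)cc2)c2ccccc12`: 3.44

Compound 3 sits level with compound 1, the two together giving the highest numbers of the three; the step of no change at the digits printed from compound 1 to compound 3 (within the scatter) shows no change, and the step of a number 0.10 log units higher from compound 2 to compound 3 (within the scatter) stays within the scatter. The three measured compounds all carry a substituted phenyl on the amine nitrogen, and none of the exchanges among them moved this assay beyond the scatter.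

The next compound, compound 4, is `CCOC(=O)C1=C(C)NC(=S)NC1c1cn(C(=O)CNc2ccccc2N)c2ccccc12`. Its change from compound 3 is 2-aminophenyl in place of 4-chlorophenyl on an amine nitrogen. The measured steps bear on it only loosely: no change at the digits printed from compound 1 to compound 3 (within the scatter) and a number 0.10 log units lower from compound 1 to compound 2 (within the scatter) exchanged one substituted phenyl for another without adding a hydrogen-bond donor, whereas the entering 2-aminophenyl brings one donor and one acceptor as counted above. For the measured compounds named here, no measured pair covers such an addition, so the expectation is less firm than the earlier steps.

Compound 4 is expected to give 2.6, within 2.1 to 3.1. The expected step is a number 0.84 log units lower from compound 3 to compound 4 (beyond the scatter), a decrease beyond the scatter.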

Compound 4, partition coefficient: 2.14
Beside the measured number, compound 4's estimate is 0.46 log units above it, within the range that was stated.
By their numbers in this assay, from the lowest: compound 4; then compounds 2, 1 and 3 (each within the scatter of the next).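

The aryl group on the amine nitrogen is not a silent position in this assay: the exchange of 4-chlorophenyl for 2-aminophenyl gives a number 1.30 log units lower from compound 3 to compound 4 (beyond the scatter) and the exchange of 2-methyl-4-nitrophenyl for 2-aminophenyl gives a number 1.20 log units lower from compound 2 to compound 4 (beyond the scatter) while the earlier exchanges among substituted phenyls all stayed within the scatter. The narrowest comparison is amino in place of chloro on an aromatic carbon, with a number 1.30 log units lower from compound 1 to compound 4 (beyond the scatter) as the step, so a change of that one group on the 2-substituted phenyl is enough to separate compound 4 from the other three compounds. The data shown offer no measured explanation for the size of this step.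

As far as these compounds go, it remains open whether the step belongs to the amino group as such or would also appear with other groups on that phenyl, such as a hydroxyl, a methylamino or a dimethylamino group. Also open, from the compounds shown here alone, is how 4-aminophenyl would compare with 2-aminophenyl, and where the unsubstituted phenyl would stand against these compounds.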